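Benzyl to 4-Methylphenyl on the Amide-Type Nitrogen of Compound 1

The source may hold more compounds than are shown below. What is called first, only, known or untested is meant among the compounds shown, and "the series" means these compounds.

Measured compounds:
compound 1, `COc1ccc(-c2cnc3nc(N)nc(N4CCN(C(=O)NCc5ccccc5)CC4)c3n2)cc1OC`: 18 nM
compound 2, `CCOc1nc(N)nc2ncc(-c3ccc(Cl)c(Cl)c3)nc12`: > 10000 nM (a limit)
compound 3, `CC(C)Oc1nc(N)nc2ncc(-c3ccc(C#N)cc3)nc12`: > 10000 nM (a limit)

Among the compounds with values here, in a functional assay on cells (T-cell, Homo sapiens) for inhibition (on this read-out lower numbers stand for stronger inhibition and higher numbers for weaker inhibition), compound 1 gives 18 nM, the only number among the three values shown. Compound 2 reaches only > 10000 nM, a limit of the assay and not a number. Compound 3 likewise stops at > 10000 nM, again a limit. Within the data shown here, both of these sit at the limit of > 10000 nM in this assay, at which 2 of the 3 values shown sit, so no step between measured compounds can be read off, and compound 1 stands alone with a number.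

Compound 4, `COc1ccc(-c2cnc3nc(N)nc(N4CCN(C(=O)Nc5ccc(C)cc5)CC4)c3n2)cc1OC`, has not yet been measured. It differs from compound 1 in a single place: 4-methylphenyl in place of benzyl on an amide-type nitrogen. The two share the same atoms, joined differently, and the change sits on the amide-type nitrogen whose other neighbour is the carbonyl carbon.

Among the measured compounds shown here, with no measured step to lean on, the expectation is a step from compound 1 to compound 4 of modest size, likely within or only just beyond the usual scatter of this assay, in either direction. Compound 4 is therefore estimated at 25 nM in this assay, with a range from 6 nM to 100 nM, which means an expected step of a 1.4-fold higher number from compound 1 to compound 4 (0.14 log units; within the scatter).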

Compound 4, half-maximal inhibitory concentration: 0.8 nM
The estimate for compound 4 lay 31-fold (1.49 log units) above the measured number, outside the stated range (below it).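

In this assay, within the data shown here, the exchange of benzyl for 4-methylphenyl on the amide-type nitrogen whose other neighbour is the carbonyl carbon gives a 23-fold lower number from compound 1 to compound 4 (1.35 log units; beyond the scatter), the first measured step and one that shows this position strongly affects the read-out. The change leaves the counts unaltered, since both groups have the same number of heavy atoms, one six-membered aromatic ring of carbon only and no hydrogen-bond donors or acceptors, so these counts do not separate the two compounds even though their numbers differ widely. Nothing measured here accounts for the size of this step.

The compounds shown leave open how much of the step belongs to the methyl group and how much to the replacement of benzyl by a ring-bearing group of the other connectivity, a question that phenyl on the same nitrogen would address. They also leave open how far the position tolerates other groups, such as 4-chlorophenyl, 4-methoxyphenyl or 2-phenylethyl, since this single pair gives no trend.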